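From compound 2 to compound 4: pyrimidine isomer swap

This account rests on a few compounds, and the source may have more. Where it says the series, first, only, none or still open, it means among the compounds named here.

Measured in a physicochemical assay for solubility; on this read-out lower numbers stand for lower solubility and higher numbers for higher solubility
- compound 1 `O=S(=O)(Nc1ncccn1)c1ccc2c(c1)OCC[C@@H]2c1ccc(C(F)(F)F)cc1-c1ccc(F)nc1` gives 408000 nM
- compound 2 `Cn1nccc1-c1cc(C(F)(F)F)ccc1[C@H]1CCOc2cc(S(=O)(=O)Nc3ncccn3)ccc21` gives 532000 nM
- compound 3 `O=S(=O)(Nc1ncccn1)c1ccc2c(c1)OCC[C@@H]2c1ccc(C(F)(F)F)cc1-c1ccc(F)cn1` gives 225000 nM

The number for compound 2 sits at the upper end of a narrow range (a 1.3-fold higher number from compound 1 to compound 2 (0.12 log units; within the scatter); a 2.4-fold lower number from compound 2 to compound 3 (0.37 log units; beyond the scatter)). The next compound is compound 4 `Cn1nccc1-c1cc(C(F)(F)F)ccc1[C@H]1CCOc2cc(S(=O)(=O)Nc3ccncn3)ccc21` with pyrimidin-4-yl in place of pyrimidin-2-yl on a sulfonamide nitrogen. Among the compounds with values here, no measured step covers this place. Within the data shown here, the only guide is indirect: swaps on an aromatic carbon elsewhere gave small steps (a 1.8-fold lower number from compound 1 to compound 3 (0.26 log units; within the scatter)), and the largest was modest. The expected step in this assay is therefore small, within the scatter and without a firm direction (a 1.2-fold lower number from compound 2 to compound 4 (0.07 log units; within the scatter)). The estimated value for compound 4 is 450000 nM (expected range 200000 nM to 1000000 nM).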

Compound 4, solubility: 1180000 nM
Beside the measured number, compound 4's estimate is 2.6-fold (0.42 log units) below it; the whole stated range lies below it.
By their numbers in this assay, from the lowest: compounds 3, 1 and 2 (each within the scatter of the next, the first and the last beyond it); then compound 4.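

The sulfonamide nitrogen is a new place for this series in this assay, and pyrimidin-4-yl in place of pyrimidin-2-yl gives a 2.2-fold higher number from compound 2 to compound 4 (0.35 log units; beyond the scatter). The read-out therefore responds to the isomer alone here, with the same heavy atoms and the same hydrogen-bond counts on both sides of the change. Nothing at hand accounts for this step.

As far as these compounds go, it remains open whether the step carries over to the 6-fluoropyridin-3-yl of compound 1 or the 5-fluoropyridin-2-yl of compound 3. From the compounds shown here alone, how a thiazol-2-yl on the sulfonamide nitrogen would read is also open.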